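Compound 4: benzyl in place of hydrogen, lipophilicity estimate

The source may hold more compounds than are shown below. What is called first, only, known or untested is meant among the compounds shown, and "the series" means these compounds.

Measured compounds:
Compound 1 `NS(=O)(=O)Oc1ccc2c(c1)CN(C(=O)c1ccc(N3CCCCC3)cc1)CC2`: in a physicochemical assay for lipophilicity (on this read-out lower numbers stand for lower lipophilicity and higher numbers for higher lipophilicity), compound 1 gives 1.93.
Compound 2 `CN(C)CCN(CCN(C)C)c1ccc(C(=O)N2CCc3ccc(OS(N)(=O)=O)cc3C2)cc1`: in this assay compound 2 gives 1.93.
Compound 3 `CCN(Cc1ccccc1)c1ccc(C(=O)N2CCc3ccc(OS(N)(=O)=O)cc3C2)cc1`: in this assay compound 3 gives 3.08.

Compound 1 stands level with compound 2 at the digits shown, the two together the lowest of the three numbers; compound 3 lies furthest away, a number 1.15 log units higher from compound 1 to compound 3 (beyond the scatter). Compound 4 `NS(=O)(=O)Oc1ccc2c(c1)CN(C(=O)c1ccc(N3CCC(Cc4ccccc4)CC3)cc1)CC2` differs from compound 1 in one place: benzyl in place of hydrogen on a saturated ring carbon. Among the compounds with values here, none of the measured steps alters a saturated ring carbon, so they bear on this change only loosely. The closest comparisons are a number 1.15 log units higher from compound 1 to compound 3 (beyond the scatter), where a benzyl group also enters, and a number 1.15 log units higher from compound 2 to compound 3 (beyond the scatter). An upward step of similar size is therefore expected, a number 1.47 log units higher from compound 1 to compound 4 (beyond the scatter). Compound 4 is expected to give 3.4 in this assay, between 2.8 and 4.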

Compound 4, partition coefficient: 3.87
Estimate against measurement, compound 4: 0.47 log units below; low and high end bracket the measured number.
By their numbers in this assay, from the lowest: compounds 1 and 2 (each within the scatter of the next); then compound 3; then compound 4.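

Working notes: the saturated ring carbon, three ring bonds from the ring nitrogen, is now shown to respond in this assay, where benzyl in place of hydrogen gives a number 1.94 log units higher from compound 1 to compound 4 (beyond the scatter) on the core of compound 1. Within the data shown here, the earlier steps only exchanged the whole amino group on an aromatic carbon; this step is the first reading at a saturated ring carbon, and it keeps the ring with 1 nitrogen intact. Open, from the compounds shown here alone, is how an amine, a carboxylic acid or a longer chain at this ring carbon would read. Nothing shown accounts for the size of this step.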